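The compounds below may be only part of what the source reports. "The series", "measured", "known", "first", "only" and "open" are said of these compounds alone.

Three compounds have been measured in a functional assay on BCG823 cells (Homo sapiens) for antiproliferative activity, read by MTT assay, with a stated time of 48 h; on this read-out lower numbers stand for stronger inhibition and higher numbers for weaker inhibition:

Compound 1 `COc1cc2oc(-c3ccccc3)cc(=O)c2c(O)c1OCCCN1CCCC1` gives 6500 nM.
Compound 2 `O=c1cc(-c2ccccc2)oc2cc(OCc3ccccc3)c(OCCCCN3CCCC3)c(O)c12` gives 3200 nM.
Compound 3 `CCN(CC)CCCOc1c(OC)cc2oc(-c3ccccc3)cc(=O)c2c1O` gives 5700 nM.

Compound 1 and compound 3 share one core and differ only in the amine at the end of the side chain: diethylamino in place of pyrrolidin-1-yl on a saturated chain carbon, three bonds along the chain from an oxygen on an aromatic ring. That change gives a 1.1-fold lower number from compound 1 to compound 3 (0.06 log units; within the scatter), a step so small that the two compounds cannot be told apart in this assay. Compound 2 carries a different core, and the difference between the two cores is not broken down here; its value and that of compound 3 lie within the scatter of each other, while its number stands beyond the scatter from that of compound 1.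

Compound 4 `CCN(CC)CCCCOc1c(OCc2ccccc2)cc2oc(-c3ccccc3)cc(=O)c2c1O` is not yet measured. It stands to compound 2 as compound 3 stands to compound 1: diethylamino in place of pyrrolidin-1-yl on a saturated chain carbon, four bonds along the chain from an oxygen on an aromatic ring. The place differs slightly, four bonds along the chain from the aromatic oxygen rather than three, so this is the same kind of change rather than the same one. Since the earlier swap gave a 1.1-fold lower number from compound 1 to compound 3 (0.06 log units; within the scatter), an equally small step is expected, a 1.1-fold lower number from compound 2 to compound 4 (0.03 log units; within the scatter). Compound 4 is therefore estimated at 3000 nM, with a range from 1500 nM to 6500 nM.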

Compound 4, half-maximal inhibitory concentration: 4200 nM
For compound 4 the middle estimate is 1.4-fold (0.15 log units) below the measured one; the range from low to high includes it.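

In this assay, the swap from pyrrolidin-1-yl to diethylamino on the second core gives a 1.3-fold higher number from compound 2 to compound 4 (0.12 log units; within the scatter), so the two compounds cannot be told apart. Set beside the earlier step, the swap reads the same on both cores, with no difference that stands out from the scatter: the same change on two cores in this assay, a 1.1-fold lower number (0.06 log units; within the scatter) from compound 1 to compound 3 and a 1.3-fold higher number (0.12 log units; within the scatter) from compound 2 to compound 4, 1.5-fold (0.18 log units) apart, within the scatter of two such steps. This shows that, in these two pairs, the change could be carried from one core to the other without a readable effect on the result, but it does not show that the two amines are interchangeable on other cores, and two steps this small cannot reveal how a change with a clear effect would carry over.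

The compounds shown leave open how other amines at the end of the chain, such as piperidine or morpholine, or a longer chain, would read. They also leave open how much each difference between the two cores contributes, as those differences are not separated here.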